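The source may hold more compounds than are shown below. What is called first, only, known or untested is meant among the compounds shown, and "the series" means these compounds.

Of the compounds shown here, three that share one core have been measured in a functional assay on WM 266-4 cells (Homo sapiens) for antiproliferative activity, read by MTT assay, with a stated time of 24 h; on this read-out higher numbers stand for weaker inhibition of growth and lower numbers for stronger inhibition of growth. Compound 1 `Clc1ccc(C2CC(c3ccc4c(c3)OCCO4)=NN2c2ccccc2)cc1` gives 38600 nM, compound 2 `c1ccc(C2CC(c3ccc4c(c3)OCCO4)=NN2c2ccccc2)cc1` gives 22400 nM, and compound 3 `Clc1cccc(C2CC(c3ccc4c(c3)OCCO4)=NN2c2ccccc2)c1` gives 1750 nM, the lowest number of the three and beyond the scatter from both others. Compound 4 `Ic1ccc(C2CC(c3ccc4c(c3)OCCO4)=NN2c2ccccc2)cc1` differs from compound 3 by 4-iodophenyl in place of 3-chlorophenyl on a saturated ring carbon. The step of a 22-fold lower number from compound 1 to compound 3 (1.34 log units; beyond the scatter) bears most directly on this change, as it exchanges 4-chlorophenyl for 3-chlorophenyl; the step of a 13-fold lower number from compound 2 to compound 3 (1.11 log units; beyond the scatter) points the same way, while a 1.7-fold lower number from compound 1 to compound 2 (0.24 log units; within the scatter) shows little difference between 4-chlorophenyl and plain phenyl. Within the data shown here, no measured pair shows chloro against iodo, so that part of the change is unknown. A large step back upward is therefore expected, a 14-fold higher number from compound 3 to compound 4 (1.15 log units; beyond the scatter). Compound 4 is estimated at 25000 nM, expected between 7000 nM and 80000 nM.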

Compound 4, concentration for 50% growth inhibition: 3470 nM
Beside the measured number, compound 4's estimate is 7.2-fold (0.86 log units) above it; the whole stated range lies above it.
By their numbers in this assay, from the lowest: compounds 3 and 4 (each within the scatter of the next); then compounds 2 and 1 (each within the scatter of the next).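

In this assay, iodo on the phenyl ring behaves differently from chloro at the same place, as the step from chloro shows (an 11-fold lower number from compound 1 to compound 4 (1.05 log units; beyond the scatter)), and so does the step from hydrogen (a 6.5-fold lower number from compound 2 to compound 4 (0.81 log units; beyond the scatter)). The comparison with the best earlier compound (a 2.0-fold higher number from compound 3 to compound 4 (0.30 log units; within the scatter)) shows that a low number on this saturated ring carbon is not unique to 3-chlorophenyl. Nothing available explains why iodo and chloro differ here. Still open, from the compounds shown here alone, is how 4-bromophenyl or 3-iodophenyl would compare, and whether a phenyl ring carrying an amine or a carboxylic acid would be tolerated.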